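The compounds below may be only part of what the source reports. "The series", "measured", "known", "first", "only" and "open" are said of these compounds alone.

Measured in a functional assay on HCT-15 cells (Homo sapiens) for antiproliferative activity, read by sulforhodamine B assay; on this read-out lower numbers stand for stronger inhibition of growth and higher numbers for weaker inhibition of growth:
- compound 1 `CC(C)CCCOc1cccc(O)c1C(=O)/C=C/c1ccc(O)cc1` gives 11600 nM
- compound 2 `CC(C)(C)CCOc1cccc(O)c1C(=O)/C=C/c1ccc(O)cc1` gives 3430 nM
- compound 3 `O=C(/C=C/c1ccc(O)cc1)c1c(O)cccc1OCCC1CCCCC1` gives > 30000 nM, which is a limit and not a number

Compound 3 thus stands at the limit of > 30000 nM in this assay, at which 1 of the 3 values shown sits. Compound 4 `O=C(/C=C/c1ccc(O)cc1)c1c(O)cccc1OCC1CCCC1` carries cyclopentyl in place of cyclohexylmethyl on a saturated chain carbon bound to an oxygen on an aromatic ring. Among the measured compounds shown here, three measured steps bear on this. The open chain ends differ in a 3.4-fold lower number from compound 1 to compound 2 (0.53 log units; beyond the scatter), and cyclohexyl raises the number in both an at least 2.5-fold higher number from compound 1 to compound 3 (0.41 log units; beyond the scatter) and an at least 8.7-fold higher number from compound 2 to compound 3 (0.94 log units; beyond the scatter). Compound 4 lacks that cyclohexyl, so a modest step towards stronger inhibition is expected. The expected step in this assay is an at least 3.3-fold lower number from compound 3 to compound 4 (0.52 log units; beyond the scatter). For compound 4 the estimated value is 9000 nM, with an expected range from 3000 nM to 30000 nM.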

Compound 4, concentration for 50% growth inhibition: 3410 nM
Estimate against measurement, compound 4: 2.6-fold (0.42 log units) above; the range from low to high includes it.
By their numbers in this assay, from the lowest: compounds 4 and 2 (each within the scatter of the next); then compound 1. At a limit, above all of these: compound 3.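

In this assay cyclopentyl in place of cyclohexylmethyl shows that a carbon ring at this place does not by itself go with weak inhibition of growth (an at least 8.7-fold lower number from compound 3 to compound 4 (0.94 log units; beyond the scatter)). Cyclopentyl cannot be told apart from neopentyl (a 1.0-fold lower number from compound 2 to compound 4 (0.00 log units; within the scatter)) and gives stronger inhibition than isopentyl (a 3.4-fold lower number from compound 1 to compound 4 (0.53 log units; beyond the scatter)). The value of compound 3 is a limit and not a number: (the limit of > 30000 nM in this assay, at which 1 of the 4 values shown sits).

The compounds shown leave open whether an amine or a carboxylic acid in place of cyclopentyl would keep this level of inhibition. They also leave open how cyclobutyl or cyclohexyl would fare here.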